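A few compounds are considered here, and "the series" means these few. Any claim that something is new, unique, unknown or untested is made for them only; others in the source may bear on it.

Measured compounds:
compound 1 `ClCc1cccc(Cn2cnc3ncnc(Cl)c32)c1` – in a functional assay on CAKI-1 cells (Homo sapiens) for cytotoxicity, read by sulforhodamine B assay, with a stated time of 48 h (on this read-out higher numbers stand for weaker inhibition of growth and lower numbers for stronger inhibition of growth), compound 1 gives 2130 nM
compound 2 `ClCc1cccc(Cn2cnc3c(Cl)ncnc32)c1` – compound 2 gives 1540 nM
compound 3 `ClCc1cccc(Cn2cnc3c(Cl)nc(Cl)nc32)c1` – compound 3 gives 2230 nM

Compound 1 and compound 2 are built from the same atoms joined differently; how the two cores differ is not broken down here, and their values lie within the usual scatter of each other. Compound 3 arises from compound 2 by one change, (chloro in place of hydrogen on an aromatic carbon), and this brought a 1.4-fold higher number from compound 2 to compound 3 (0.16 log units; within the scatter). The same change applied to compound 1 gives compound 4 `ClCc1cccc(Cn2cnc3nc(Cl)nc(Cl)c32)c1`, not yet measured: chloro in place of hydrogen on an aromatic carbon. Since the earlier step stayed within the scatter, the step from compound 1 to compound 4 is expected to be small, about a 1.3-fold higher number from compound 1 to compound 4 (0.10 log units; within the scatter). Compound 4 is therefore estimated at 2700 nM, with a likely range from 1500 nM to 5000 nM.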

Compound 4, concentration for 50% growth inhibition: 1860 nM
Beside the measured number, compound 4's estimate is 1.5-fold (0.16 log units) above it; measured number inside the range.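

In this assay, chloro in place of hydrogen on the aromatic carbon between two ring nitrogen atoms gives a 1.1-fold lower number from compound 1 to compound 4 (0.06 log units; within the scatter), so this step is small. Set beside the same change on the other core, the two steps do not differ beyond the scatter: the same change on two cores in this assay, a 1.4-fold higher number (0.16 log units; within the scatter) from compound 2 to compound 3 and a 1.1-fold lower number (0.06 log units; within the scatter) from compound 1 to compound 4, 1.7-fold (0.22 log units) apart, within the scatter of two such steps This fits a change that carries across these two cores by leaving the number about where it stood, but with only two small steps it does not show that the two cores respond alike to changes with a larger effect, or that other cores would behave the same way.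

The compounds shown leave open whether an amine or a methoxy group on that same carbon would shift the number beyond the scatter, and whether such a shift would carry from one core to the other.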